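Trading tert-butyl for ethoxy

A few compounds are considered here, and "the series" means these few. Any claim that something is new, unique, unknown or untested is made for them only; others in the source may bear on it.

Going by the values given here, in a functional assay on SK-MEL-5 cells (Homo sapiens) for cytotoxicity (on this read-out lower numbers stand for an effect already at smaller amounts and higher numbers for an effect only at larger amounts of compound), compound 1 `COc1cc(/C=C\c2ccc(C(C)(C)C)cc2)cc(OC)c1OC` gives 2.1 uM as the only actual number so far. Compound 2 `COc1cc(/C=C/c2ccc(C(C)(C)C)cc2)cc(OC)c1OC` reads > 25 uM and that is a limit of the assay. The large step of an at least 11-fold higher number from compound 1 to compound 2 (1.07 log units; beyond the scatter) goes with the fact that compounds 1 and 2 differ only in the configuration as drawn and leaves the Z double bond of compound 1 as the form with a measured number. Compound 3 `CCOc1ccc(/C=C\c2cc(OC)c(OC)c(OC)c2)cc1` keeps that Z double bond but carries ethoxy in place of tert-butyl on an aromatic carbon as its change: ethoxy in place of tert-butyl on an aromatic carbon. Among the compounds with values here, no measured step covers this swap, so the large step bears on it only through the retained double bond. With compound 1 at 2.1 uM as the anchor, compound 3 is expected to stay measurable. A modest step toward a lower number is expected as a 2.3-fold lower number from compound 1 to compound 3 (0.37 log units; beyond the scatter) in this assay and remains uncertain. In this assay the estimated value for compound 3 is 0.9 uM with 0.1 uM to 6 uM as its expected range.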

Compound 3, concentration for half-maximal effect: 2.5 uM
Compound 3: the middle estimate sits 2.8-fold (0.44 log units) below what was measured, within the range that was stated.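

The change from tert-butyl to ethoxy on an aromatic carbon, para to a large group, appears in this assay as a 1.2-fold higher number from compound 1 to compound 3 (0.08 log units; within the scatter) and so stays within the scatter. The earlier pair varied only the double bond, whereas this pair keeps the Z double bond and shows that this position can take ethoxy, with its oxygen and one hydrogen-bond acceptor, in place of the all-carbon tert-butyl without a reading beyond the scatter. Nothing shown accounts for this result.

From the compounds shown here alone, it remains open whether the same position would tolerate an amine, a carboxylic acid or a longer chain such as butoxy. Going by these compounds, it also remains open whether the ethoxy group would show the same dependence on the double-bond configuration that the tert-butyl pair shows.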